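This account rests on a few compounds, and the source may have more. Where it says the series, first, only, none or still open, it means among the compounds named here.

Compound 1 `COc1ccc(-n2ccnc2SCC(=O)Nc2ccccc2Br)cc1`: > 298000 nM in an ADME assay on MT4 cells (Homo sapiens) for cytotoxicity, read by MTT assay (a higher number here means that more compound is tolerated, a lower number that less compound is tolerated), a limit of the assay.
Compound 2 `Cc1ccc(-n2ccnc2SCC(=O)Nc2ccccc2Br)cc1`: 39300 nM in this assay.
Compound 3 `Cc1ccc(-n2ccnc2SCC(=O)Nc2ccccc2C)cc1`: 147000 nM in this assay.

Compound 1 stands only as a limit in this assay, (the limit of > 298000 nM in this assay, at which 1 of the 3 values shown sits), so its true value is open upward. Compound 4 `COc1ccc(-n2ccnc2SCC(=O)Nc2ccc(C)cc2Br)cc1` differs from compound 1 by methyl in place of hydrogen on an aromatic carbon. Neither measured step bears on this change directly: an at least 7.5-fold lower number from compound 1 to compound 2 (0.87 log units; beyond the scatter) alters the group on the other ring, and a 3.7-fold higher number from compound 2 to compound 3 (0.57 log units; beyond the scatter) exchanges the bromo group rather than adding a methyl to that ring. Both steps are modest, so a methyl added to the bromophenyl ring is expected to move the number little, with a step of an at least 1.1-fold lower number from compound 1 to compound 4 (0.07 log units; that floor lies within the scatter) expected from compound 1 to compound 4. Compound 4 is therefore expected near 250000 nM, within 80000 nM to 700000 nM, and another limit is plausible.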

Compound 4, half-maximal cytotoxic concentration: 25800 nM
Beside the measured number, compound 4's estimate is 9.7-fold (0.99 log units) above it; measured number outside the range, below it.
By their numbers in this assay, from the lowest: compounds 4 and 2 (each within the scatter of the next); then compound 3. At a limit, above all of these: compound 1.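

In this assay, within the data shown here, going from 2-bromophenyl to 2-bromo-4-methylphenyl gives an at least 11-fold lower number from compound 1 to compound 4 (1.06 log units; beyond the scatter), so a single added methyl at this position, on a ring whose substitution the earlier steps changed only at the bromo group, is enough to produce a large change. The true size of this step stays open, since compound 1 stands at a limit of the assay: the limit of > 298000 nM in this assay, at which 1 of the 4 values shown sits.

On these data alone, whether an amine, a fluoro group or a longer chain at this position would shift the number as far remains open. Also open, as far as these compounds go, is whether the same added methyl would have a like effect on compound 2 or compound 3.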